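A few compounds are considered here, and "the series" means these few. Any claim that something is new, unique, unknown or untested is made for them only; others in the source may bear on it.

Series notes. Compound 1 `C[C@@H](NC(=O)c1ccc(C#Cc2cccnc2)cn1)C(C)(C)O` and compound 2 `C[C@@H](NC(=O)c1ccc(C#Cc2ccncc2)cn1)C(C)(C)O` share one core and differ only in the ring on the triple-bonded carbon. In an ADME assay on HEK293 cells for agonist activity at metabotropic glutamate receptor 5 (Rattus norvegicus), read by fluorescence and calcium flux (on this read-out lower numbers stand for smaller maximal responses and higher numbers for larger maximal responses), compound 1 gives 25.9%, and in this assay compound 2 gives 22.4%. Among the measured compounds shown here, the only measured step is a number 3.5 percentage points lower from compound 1 to compound 2 (within the scatter), and it lies within the scatter. Compound 2 thus holds the lower of the two numbers, though it is not set apart from compound 1 by any margin that counts.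

Compound 3 `C[C@@H](NC(=O)c1ccc(C#Cc2cc(F)ccn2)cn1)C(C)(C)O` is not yet measured. It differs from compound 2 by 4-fluoropyridin-2-yl in place of pyridin-4-yl on a triple-bonded carbon. For the measured compounds named here, the one measured step bears on it only loosely: exchanging pyridin-3-yl for pyridin-4-yl did not move the response beyond the scatter, so for this assay no step beyond the scatter is expected here either. For compound 3 the expected value in this assay is 24%, between 12% and 38%. The step of a number 1.6 percentage points higher from compound 2 to compound 3 (within the scatter) is therefore estimated to be small.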

Compound 3, largest response reached (reported as efficacy), in percent of the reference or control that the assay uses: 33%
Estimate against measurement, compound 3: 9 percentage points below; the range from low to high includes it.
By their numbers in this assay, from the lowest: compounds 2, 1 and 3 (each within the scatter of the next, the first and the last beyond it).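

In this assay, the ring on the triple-bonded carbon now yields a step beyond the scatter, with 4-fluoropyridin-2-yl in place of pyridin-4-yl: a number 10.6 percentage points higher from compound 2 to compound 3 (beyond the scatter). With the same group in place of pyridin-3-yl the step is a number 7.1 percentage points higher from compound 1 to compound 3 (within the scatter), so 4-fluoropyridin-2-yl is set apart from only one of the two earlier rings and does not clearly top the series. No supporting data bear on what lies behind the larger step.

On these data alone, the fluorine and the point of attachment to the pyridine ring change together here, so the share of each remains open. Also open, as far as these compounds go, is how plain pyridin-2-yl, or a chlorine or methoxy group in place of the fluorine, would read out at this position.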